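Swapping one halogen for another on two different cores

The source may report more compounds than this note shows. Statements on the series, on what has been measured and on what is new or still open speak of the compounds shown alone.

Of the compounds shown here, three have been measured in a functional assay on MCF7 cells (Homo sapiens) for inhibition; a higher number here means a weaker inhibitor, a lower number a stronger inhibitor. Compound 1 `COc1ccc(-c2nc3cc(F)ccc3s2)cc1Cl` gives 760 nM. Compound 2 `COc1ccc(-c2nc3cc(F)ccc3s2)cc1Br` gives 850 nM. Compound 2 differs from compound 1 by a single change:

bromo in place of chloro on an aromatic carbon

This change made a step of a 1.1-fold higher number from compound 1 to compound 2 (0.05 log units; within the scatter), so the two compounds cannot be told apart by their numbers.

Compound 3 `COc1ccc(-c2nc3cc(Cl)ccc3s2)cc1OC` is built on a different core; how its core differs from that of compound 1 is not broken down here. In this assay compound 3 gives 27900 nM, the highest of the three numbers and beyond the scatter from both compound 1 and compound 2.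

Compound 4 `COc1ccc(-c2nc3cc(Br)ccc3s2)cc1OC` has not yet been measured. It differs from compound 3 by the following change:

bromo in place of chloro on an aromatic carbon

This is the same kind of change as that from compound 1 to compound 2, but not the same: there the place was on a six-membered aromatic ring of carbon only, ortho to a methoxy group and meta to a large group, while here the place is part of a fused or bridged system of two rings, meta to a fused ring and para to a fused ring. Within the data shown here, the only guidance is the single earlier step, which was within the scatter. The expected step is a 1.0-fold higher number from compound 3 to compound 4 (0.00 log units; within the scatter), resting on the step of a 1.1-fold higher number from compound 1 to compound 2 (0.05 log units; within the scatter) seen between compound 1 and compound 2. Compound 4 is therefore expected to give 28000 nM in this assay. The estimate for compound 4 is expected to fall between 12000 nM and 65000 nM.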

Compound 4, half-maximal inhibitory concentration: 13600 nM
For compound 4 the middle estimate is 2.1-fold (0.31 log units) above the measured one, within the range that was stated.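

In this assay putting bromo in place of chloro on the core of compound 3 gives a modest step of a 2.1-fold lower number from compound 3 to compound 4 (0.31 log units; beyond the scatter) while the same kind of change on the core of compound 1 gave a step of a 1.1-fold higher number from compound 1 to compound 2 (0.05 log units; within the scatter) and left those two compounds indistinguishable. One step lies within the scatter and the other just beyond it, yet the gap between them is too small to count as a real difference, so nothing here shows that the core alters what this change does: the same change on two cores in this assay, a 1.1-fold higher number (0.05 log units; within the scatter) from compound 1 to compound 2 and a 2.1-fold lower number (0.31 log units; beyond the scatter) from compound 3 to compound 4, 2.3-fold (0.36 log units) apart, within the scatter of two such steps. Among these compounds, this does not prove that the change behaves alike on both cores, let alone on others, as there is only one pair of compounds on each core and the halogen sits in a different place in each pair.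

The compounds shown leave open what other groups would do at these two places, such as iodo, a nitrile, a methyl or an amine in place of the halogen. They also leave open whether bromo in place of chloro on a third core would give a step closer to the first of these two or to the second.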